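Thioether benzamides and the acrylamide step

This account rests on a few compounds, and the source may have more. Where it says the series, first, only, none or still open, it means among the compounds named here.

Compound 1 `Nc1ccccc1NC(=O)c1ccc(CSc2ccc(Br)cc2)cc1` gives 67.7% in a functional assay on HCT-116 cells (Homo sapiens) for inhibition, read by CCK-8 assay, with a stated time of 72 h, tested at 8 uM; on this read-out higher numbers stand for more inhibition of growth at the one concentration tested and lower numbers for less inhibition of growth. Compound 3 `CC(C)(C)c1ccc(SCc2ccc(C(=O)Nc3ccccc3N)cc2)cc1` gives 60.5% in this assay; the single-change step between them, a number 7.2 percentage points lower from compound 1 to compound 3 (within the scatter), is within the scatter. Compound 2 `Nc1ccccc1NC(=O)/C=C/c1ccc(CSc2ccc(Cl)cc2)cc1` gives 3.27%, the lowest of the three numbers, beyond the scatter below compound 3 and further below compound 1. Compound 4 `Nc1ccccc1NC(=O)/C=C/c1ccc(CSc2ccc(C(F)(F)F)cn2)cc1` has not yet been measured in this assay; it differs from compound 2 by 5-(trifluoromethyl)pyridin-2-yl in place of 4-chlorophenyl on a sulfur. Within the data shown here, the only measured step that touches the group on the sulfur, a number 7.2 percentage points lower from compound 1 to compound 3 (within the scatter), was within the scatter, so no step beyond the scatter is expected in this assay from this change. Compound 4 is therefore estimated at 10%, with an expected range of 0% to 30%, an expected step of a number 6.7 percentage points higher from compound 2 to compound 4 (within the scatter).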

Compound 4, percent growth inhibition at one concentration: 14.9%
Compound 4: middle estimate off by 4.9 percentage points, on the low side; the range from low to high includes it.
By their numbers in this assay, from the lowest: compound 2; then compound 4; then compounds 3 and 1 (each within the scatter of the next).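

In this assay, among these compounds, the group on the sulfur can move the read-out: 5-(trifluoromethyl)pyridin-2-yl in place of 4-chlorophenyl gives a number 11.6 percentage points higher from compound 2 to compound 4 (beyond the scatter), whereas the only earlier step at this position, a number 7.2 percentage points lower from compound 1 to compound 3 (within the scatter), did not clear the scatter. The new step is small, and it is seen on the core of compound 2 only. No measurement at hand accounts for it.

From the compounds shown here alone, it remains open whether 5-(trifluoromethyl)pyridin-2-yl on the sulfur gives a similar step on the core of compound 1. Going by these compounds, it also remains open how an aromatic ring carrying an amine or a carboxylic acid would read at this position.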